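This account rests on a few compounds, and the source may have more. Where it says the series, first, only, none or still open, it means among the compounds named here.

Measured in a functional assay on HT-1080 cells (Homo sapiens) for cytotoxicity, read by MTT assay, with a stated time of 72 h; a lower number here means a stronger inhibitor, a higher number a weaker inhibitor:

- compound 1 `COc1cc(O)c(C)c2c1CC[C@H](c1ccc(O)cc1)O2`: 37000 nM
- compound 2 `COc1ccc(CCC(=O)c2ccc(O)cc2)c(OC)c1`: > 100000 nM (a limit of the assay, not a number)
- compound 3 `COc1cc2c(cc1O)C[C@@H](Cc1ccc(O)cc1)CO2`: 17500 nM

Only two of these three results are actual numbers, and compound 1 holds the higher of them at 37000 nM. Compound 3 is the nearest, with a lower number of 17500 nM, and this gap lies beyond the usual scatter. Both are weak results on this read-out. Compound 2 gives > 100000 nM, which is a limit.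

The next compound to be tested, compound 4 `Cc1c(O)ccc2c1O[C@@H](c1ccc(O)cc1)CC2`, keeps the core of compound 1 but carries hydrogen in place of methoxy on an aromatic carbon. Going by the values given here, no measured pair in this small set isolates that change, so the expectation rests on the starting value alone. The step of a 1.1-fold higher number from compound 1 to compound 4 (0.03 log units; within the scatter) is expected to be small, with neither direction favoured and quite possibly nothing beyond the scatter. Any estimate must also reckon with the limit of > 100000 nM in this assay, at which 1 of the 3 values shown sits, since a weak compound could end up reported only as a limit. For compound 4 the expected value in this assay is 40000 nM, with an estimated range of 15000 nM to 100000 nM.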

Compound 4, half-maximal inhibitory concentration: 24100 nM
Estimate against measurement, compound 4: 1.7-fold (0.22 log units) above, within the range that was stated.
By their numbers in this assay, from the lowest: compounds 3, 4 and 1 (each within the scatter of the next, the first and the last beyond it). At a limit, above all of these: compound 2.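

In this assay, going by these compounds alone, hydrogen in place of methoxy on an aromatic carbon gives a 1.5-fold lower number from compound 1 to compound 4 (0.19 log units; within the scatter), the first step in this set that isolates a single place on the core of compound 1. The two compounds cannot be told apart on this read-out, so the methoxy at this carbon, ortho to a fused ring, meta to a hydroxy group and para to a methyl group, shows no measurable part in the cytotoxicity of compound 1 in this one comparison. Compound 4 is also reported as an actual number and not as a limit, so losing the methoxy does not take it out of the measurable range: the limit of > 100000 nM in this assay, at which 1 of the 4 values shown sits.

The compounds shown leave open whether any other group on this carbon, such as an amine, a carboxylic acid or a longer alkoxy chain, would shift the number beyond the scatter. Within the data shown here, they also leave open what the hydroxy and methyl groups on the same ring contribute, as compounds 2 and 3 differ from compound 1 in more than one place and no step isolates either group.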